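Swapping a urea for an amide on a shared core

The source may report more compounds than this note shows. Statements on the series, on what has been measured and on what is new or still open speak of the compounds shown alone.

In a functional assay on UACC-257 cells (Homo sapiens) for antiproliferative activity, read by sulforhodamine B assay, with a stated time of 48 h (a lower number here means a stronger inhibitor, a higher number a weaker inhibitor), compound 1, `COc1cc(-c2nn(-c3ccc(NC(=O)c4ccc(Cl)c(Cl)c4)cc3)cc2-c2ccncc2)ccc1Cl`, gives only a limit of > 100000 nM and no number. Among the compounds with values here, compound 2, `O=C(Nc1ccc(-n2cc(-c3ccncc3)c(-c3ccc(Cl)c(O)c3)n2)cc1)Nc1ccc(Cl)c(C(F)(F)F)c1`, gives 1510 nM, the only finite value in this set. Compound 3, `O=C(Nc1ccc(-n2cc(-c3ccncc3)c(-c3ccc(Cl)c(O)c3)n2)cc1)c1ccc(Cl)c(Cl)c1`, differs from compound 2 by 3,4-dichlorophenyl in place of (4-chloro-3-(trifluoromethyl)phenyl)amino on a carbonyl carbon. Within the data shown here, no measured pair shows this change directly, so the expected size of the step rests on little. For compound 3 a weakening beyond the usual scatter is expected, with the step from compound 2 to compound 3 estimated at a 5.3-fold higher number from compound 2 to compound 3 (0.72 log units; beyond the scatter), giving compound 3 an estimated 8000 nM within a range of 2000 nM to 40000 nM in this assay.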

Compound 3, half-maximal inhibitory concentration: 4740 nM
Compound 3: the middle estimate sits 1.7-fold (0.23 log units) above what was measured, and the stated range covers the measured number.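

In this assay, replacing the urea of compound 2 with the amide of compound 3 weakens the compound but does not abolish activity: a 3.1-fold higher number from compound 2 to compound 3 (0.50 log units; beyond the scatter). With the amide in place, the step of hydrogen in place of methyl on the oxygen is the larger one: an at least 21-fold lower number from compound 1 to compound 3 (1.32 log units; beyond the scatter). The figure for compound 1 is a limit, not a measured number: the limit of > 100000 nM in this assay, at which 1 of the 3 values shown sits.

The step from compound 2 removes the urea nitrogen and replaces trifluoromethyl with chlorine at once, and the compounds shown do not separate the two. Going by these compounds, how a plain phenyl or a cyclohexyl ring on the carbonyl carbon would compare stays open.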